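This account rests on a few compounds, and the source may have more. Where it says the series, first, only, none or still open, it means among the compounds named here.

Measured so far:

compound 1, `O=c1c2cnn(-c3ccc(F)cc3)c2ncn1CC1(O)CCN(Cc2ccccc2F)CC1`: 9800 nM
compound 2, `O=c1c2cnn(-c3ccc(F)cc3)c2ncn1CC1(O)CCN(Cc2ccc(Cl)cc2)CC1`: 8000 nM

Of the compounds shown here, two have been measured in an assay on Sf21 cells for inhibition of ubiquitin carboxyl-terminal hydrolase 7 (Homo sapiens), read by spectrophotometry, with stated times of 30 min and 2 h; on this read-out higher numbers stand for weaker inhibition and lower numbers for stronger inhibition. Compound 1 is `O=c1c2cnn(-c3ccc(F)cc3)c2ncn1CC1(O)CCN(Cc2ccccc2F)CC1` and gives 9800 nM in this assay. Compound 2 is `O=c1c2cnn(-c3ccc(F)cc3)c2ncn1CC1(O)CCN(Cc2ccc(Cl)cc2)CC1` and gives 8000 nM. Within the data shown here, the single step between them, a 1.2-fold lower number from compound 1 to compound 2 (0.09 log units; within the scatter), is a change of 4-chlorophenyl in place of 2-fluorophenyl on a saturated chain carbon bound to an amine nitrogen in a ring; the two numbers lie within the scatter of each other, so nothing can be read from them about one halogen pattern against another.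

The next compound, compound 3, is `O=c1c2cnn(-c3ccc(F)cc3)c2ncn1CC1(O)CCN(Cc2ccc(Br)cc2)CC1`. It differs from compound 2 by bromo in place of chloro on an aromatic carbon. Among the measured compounds shown here, the only step in hand, from compound 1 to compound 2, moved a halogen and changed its kind at once and stayed within the scatter; a change of halogen alone at the same place is therefore expected to give a step of similar size or none beyond the scatter. For compound 3 the step of a 1.1-fold lower number from compound 2 to compound 3 (0.06 log units; within the scatter) is expected, and compound 3 is estimated at 7000 nM, with a range from 3000 nM to 18000 nM.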

Compound 3, half-maximal inhibitory concentration: 6700 nM
Compound 3: middle estimate off by 1.0-fold (0.02 log units), on the high side; the measured number falls inside the stated range.
By their numbers in this assay, from the lowest: compounds 3, 2 and 1 (each within the scatter of the next).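

In this assay, bromo in place of chloro on an aromatic carbon, para to a large group, gives a 1.2-fold lower number from compound 2 to compound 3 (0.08 log units; within the scatter) and so changes the halogen alone at one place, which the earlier step between compound 1 and compound 2 did not do; at this place, the exchange of these two halogens cannot be told from no change at all. The wider step, a 1.5-fold lower number from compound 1 to compound 3 (0.17 log units; within the scatter) for 4-bromophenyl in place of 2-fluorophenyl, also stays within the scatter, so the three benzyl groups shown, each carrying a single halogen, cannot be ranked against one another. Nothing available offers an explanation for these numbers.

The compounds leave open whether a group other than a halogen at this place, such as a methoxy group, a nitrile, an amine or a carboxylic acid, would give a step beyond the scatter. They also leave open whether replacing the benzyl group on the ring nitrogen with a longer chain, or a change elsewhere on the shared core, would do so.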